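Swapping a Chloro for a Methoxy on the Sulfonyl Aryl Ring

A few compounds are considered here, and "the series" means these few. Any claim that something is new, unique, unknown or untested is made for them only; others in the source may bear on it.

Of the compounds shown here, two sharing one core have been measured in a functional assay on CHO.K1 cells for antagonist activity at prostaglandin D2 receptor 2 (Homo sapiens), read by GTPgammaS binding, with a stated time of 1 h; on this read-out lower numbers stand for stronger inhibition and higher numbers for weaker inhibition. Compound 1 `Cc1c(Cc2ccccc2S(=O)(=O)c2ccccc2F)c2c(n1CC(=O)O)CCNC2=O` carries a 2-fluorophenyl on the sulfonyl sulfur, and in this assay compound 1 gives 3.6 nM. Compound 2 `Cc1c(Cc2ccccc2S(=O)(=O)c2ccc(Cl)cc2)c2c(n1CC(=O)O)CCNC2=O` carries a 4-chlorophenyl in that position, and in this assay compound 2 gives 8.5 nM. Among the compounds with values here, the only step so far, a 2.4-fold higher number from compound 1 to compound 2 (0.37 log units; beyond the scatter), shows that moving from the 2-fluorophenyl to the 4-chlorophenyl weakens inhibition by a modest amount. Compound 2 thus stands at the higher of the two numbers.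

Compound 3 `COc1ccc(S(=O)(=O)c2ccccc2Cc2c3c(n(CC(=O)O)c2C)CCNC3=O)cc1` differs from compound 2 in one place: methoxy in place of chloro on an aromatic carbon. Within the data shown here, no measured step compares two different groups at this same position, so the one step available, a 2.4-fold higher number from compound 1 to compound 2 (0.37 log units; beyond the scatter), only suggests that changes on this ring shift this assay by a modest amount. A small shift, in either direction, is the most that can be expected, most likely within the scatter.

Compound 3 is therefore expected to give about 10 nM in this assay, with a range from 4 nM to 25 nM, corresponding to an expected step of a 1.2-fold higher number from compound 2 to compound 3 (0.07 log units; within the scatter).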

Compound 3, half-maximal inhibitory concentration: 3.9 nM
The estimate for compound 3 lay 2.6-fold (0.41 log units) above the measured number; the whole stated range lies above it.
By their numbers in this assay, from the lowest: compounds 1 and 3 (each within the scatter of the next); then compound 2.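

Within the data shown here, exchanging chloro for methoxy on the sulfonyl aryl ring is the first comparison of two groups at this one carbon, and in this assay it gives a 2.2-fold lower number from compound 2 to compound 3 (0.34 log units; beyond the scatter), so a change of only a small group here is enough to move the number beyond the scatter. The same exchange also brings the series back to where it started: a 1.1-fold higher number from compound 1 to compound 3 (0.03 log units; within the scatter), which means the 4-methoxyphenyl and the 2-fluorophenyl on the sulfonyl sulfur cannot be told apart in this assay, while the 4-chlorophenyl of compound 2 stands apart from both. Nothing shown here speaks to the reason for the difference between chloro and methoxy.

Among these compounds, with only two groups compared at this carbon, no trend can be drawn, and a hydroxyl, an amine or a longer chain such as ethoxy in the same place would show how far the number can move in either direction. Compound 1 differs from the others in both the group and its place on the ring, so a fluoro in the place held by chloro and methoxy would be needed to separate those two changes.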